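Cyano in place of nitro on compound 2

This account rests on a few compounds, and the source may have more. Where it says the series, first, only, none or still open, it means among the compounds named here.

- compound 1 `CC1(C)[C@@H](Cn2cnc3c(O)nc(N)nc32)CC[C@@]1(C)CO` gives > 200000 nM (a limit, not a number)
- compound 2 `O=c1[nH]c(=O)n([C@H]2C[C@H](O)[C@@H](CO)O2)cc1[N+](=O)[O-]` gives 130 nM

Both readings come from an ADME assay on L1210/0 cells (Mus musculus) for cytotoxicity, with a stated time of 48 h; a lower number here means a stronger inhibitor, a higher number a weaker inhibitor. Within the data shown here, compound 2 stands at 130 nM and holds the only true number so far. Compound 1 gives > 200000 nM in this assay and this is a limit of the assay only.

Next in line is compound 3 (`N#Cc1cn([C@H]2C[C@H](O)[C@@H](CO)O2)c(=O)[nH]c1=O`), which differs from compound 2 in one place: cyano in place of nitro on an aromatic carbon. Among the measured compounds shown here, no measured step covers this change, so the expectation rests on judgement alone. A weaker reading well beyond the usual scatter is expected, with an estimated 150-fold higher number from compound 2 to compound 3 (2.19 log units; beyond the scatter) in this direction. For compound 3 the estimated value is 20000 nM, with an expected range of 1500 nM to 200000 nM in this assay.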

Compound 3, half-maximal inhibitory concentration: > 200000 nM
Compound 3 gave a limit, no number (the forecaster's own chance of this, stated with the estimate: 25%); middle value at least 10-fold (1.00 log units) away from the limit.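

In this assay, among these compounds, this aromatic carbon is the first place where a single change can be read: cyano in place of nitro gives an at least 1500-fold higher number from compound 2 to compound 3 (3.18 log units; beyond the scatter). The potency of compound 2 is therefore not carried by the shared core alone and is lost when nitro gives way to cyano at this position. The reading for compound 3 is a limit of the assay and not a number, so the step gives only a lower bound on the gap: the limit of > 200000 nM in this assay, at which 2 of the 3 values shown sit.

Going by these compounds, how far compound 3 lies past that limit remains unknown. Also open, on these data alone, is whether potency at this position is specific to nitro, or whether an amine, a carboxylic acid, a methyl group or a halogen such as bromine would retain it.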